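A few compounds are considered here, and "the series" means these few. Any claim that something is new, unique, unknown or untested is made for them only; others in the source may bear on it.

Compound 2 `O=c1c2ccccc2nc(-c2ccccc2)n1/N=C/c1ccc(Oc2ccc([N+](=O)[O-])cc2)cc1` stands at the top of the two numbers recorded in a physicochemical assay for lipophilicity, in phosphate buffer, measured as octanol-water partition; on this read-out higher numbers stand for higher lipophilicity and lower numbers for lower lipophilicity. In this assay compound 2 gives 6.12. Among the measured compounds shown here, its only companion, compound 1 `Cc1nc2ccccc2c(=O)n1/N=C/c1ccc(Oc2ccc3ccccc3c2)cc1`, gives 5.22 in this assay, a number that lies lower than the one for compound 2 by a margin wider than the usual scatter; the two compounds differ in more than one place, so the gap between them is not tied to any single change.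

Compound 3 `Cc1nc2ccccc2c(=O)n1/N=C/c1ccc(Oc2ccc([N+](=O)[O-])cc2)cc1` has not yet been measured in this assay. It is related to compound 2 by one change: methyl in place of phenyl on an aromatic carbon. For the measured compounds named here, no measured pair in this set differs in exactly this way, so the size of the step has to be judged from the starting point of compound 2 alone. A decrease in this assay beyond the scatter is expected, since compound 2 sits at 6.12 and the group leaving is the larger one. The estimated step of a number 1.62 log units lower from compound 2 to compound 3 (beyond the scatter) reflects this expectation. For compound 3 the expected value in this assay is 4.5, most probably falling between 3.8 and 5.2.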

Compound 3, partition coefficient: 4.01
The estimate for compound 3 lay 0.49 log units above the measured number; the measured number falls inside the stated range.
By their numbers in this assay, from the lowest: compound 3; then compound 1; then compound 2.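

In this assay, the position between two ring nitrogen atoms now has a measured step: methyl in place of phenyl gives a number 2.11 log units lower from compound 2 to compound 3 (beyond the scatter), a large change beyond the scatter, so what sits at this position matters on this read-out. The group on the oxygen matters as well, since 4-nitrophenyl in place of naphthalen-2-yl gives a number 1.21 log units lower from compound 1 to compound 3 (beyond the scatter), also large and beyond the scatter, and compound 3 thereby links two compounds that differ in more than one place and could not be compared directly. Nothing measured for these compounds accounts for either step.

As far as these compounds go, only methyl and phenyl are seen at the position between the ring nitrogen atoms, so it remains open how an amine, a methoxy group or a longer alkyl chain would read there in this assay. Also open, from the compounds shown here alone, is whether the change on the oxygen would give a step of similar size with phenyl rather than methyl on the core, and how a carboxylic acid or a nitrile in place of the nitro group would read.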